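Where Compound 4 Should Land After the Benzyl Swap

The source may hold more compounds than are shown below. What is called first, only, known or untested is meant among the compounds shown, and "the series" means these compounds.

Compound 1, `COc1cc(Cn2cc(CNC(=O)c3cn(-c4ccccc4)nc3-c3ccc(F)cc3)nn2)cc(OC)c1`, in a functional assay on MIA PaCa-2 cells (Homo sapiens) for antiproliferative activity, read by sulforhodamine B assay, with a stated time of 48 h (on this read-out lower numbers stand for stronger inhibition of growth and higher numbers for weaker inhibition of growth), gives 190 nM.
Compound 2, `O=C(NCc1cn(Cc2ccc(Cl)cc2)nn1)c1cn(-c2ccccc2)nc1-c1ccc(Cl)cc1`, in this assay gives 410 nM.
Compound 3, `O=C(NCc1cn(Cc2ccc(C(F)(F)F)cc2)nn1)c1cn(-c2ccccc2)nc1-c1ccc(Cl)cc1`, in this assay gives 1100 nM.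

Compound 3 stands at the highest number of the three; its nearest neighbour is compound 2, and compound 1 lies furthest from it. For the measured compounds named here, the one measured step that is a single change, a 2.7-fold higher number from compound 2 to compound 3 (0.43 log units; beyond the scatter), shows that putting trifluoromethyl in place of chloro on the benzyl ring pushed the number up by a modest amount, beyond the scatter.

Compound 4, `COc1cc(Cn2cc(CNC(=O)c3cn(-c4ccccc4)nc3-c3ccc(Cl)cc3)nn2)cc(OC)c1`, is the unmeasured compound. It differs from compound 3 in one place: 3,5-dimethoxyphenyl in place of 4-(trifluoromethyl)phenyl on a saturated chain carbon bound to an aromatic nitrogen. The same dimethoxybenzyl group is present in compound 1, which carries fluoro rather than chloro on the other aromatic ring and gives the lowest number of the set. Going by the values given here, no measured step covers that pairing directly, so only the two values can be compared. Since the step from compound 2 to compound 3 cost potency and compound 1 with the dimethoxybenzyl group sits lowest, compound 4 is expected to recover the ground lost, with a step of a 3.9-fold lower number from compound 3 to compound 4 (0.59 log units; beyond the scatter) downward. For compound 4 the estimate is 280 nM, within 120 nM to 650 nM.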

Compound 4, concentration for 50% growth inhibition: 340 nM
Estimate against measurement, compound 4: 1.2-fold (0.08 log units) below; the range from low to high includes it.
By their numbers in this assay, from the lowest: compounds 1, 4 and 2 (each within the scatter of the next, the first and the last beyond it); then compound 3.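

At the place on a saturated chain carbon bound to an aromatic nitrogen, the exchange of 4-(trifluoromethyl)phenyl for 3,5-dimethoxyphenyl in this assay comes to a 3.2-fold lower number from compound 3 to compound 4 (0.51 log units; beyond the scatter), whereas the exchange of 4-chlorophenyl for 3,5-dimethoxyphenyl comes to a 1.2-fold lower number from compound 2 to compound 4 (0.08 log units; within the scatter), so among these three groups, all with chloro on the other aromatic ring, only 4-(trifluoromethyl)phenyl stands apart. With 3,5-dimethoxyphenyl held fixed, the exchange of fluoro for chloro on an aromatic carbon gives a 1.8-fold higher number from compound 1 to compound 4 (0.25 log units; within the scatter), so the assay does not tell these two halogens apart in this pair, and the value of compound 1 cannot be credited to fluoro. Nothing on hand accounts for why 4-(trifluoromethyl)phenyl stands apart from the other two groups.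

As far as these compounds go, it remains open how this place would respond to a plain unsubstituted phenyl, to a single methoxy group, or to a phenyl ring carrying an amine or a carboxylic acid. From the compounds shown here alone, it is also open whether 4-chlorophenyl and 4-(trifluoromethyl)phenyl would still differ with fluoro in place of chloro on the other aromatic ring.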